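A Sulfonyl Group Exchange at the Clearance Limit

The compounds below may be only part of what the source reports. "The series", "measured", "known", "first", "only" and "open" are said of these compounds alone.

In an ADME assay (liver) for metabolic stability, with Liver microsome (Homo sapiens) as the target, read by LC-MS, using microsomes and NADPH, with a stated time of 5 min, at 37 degrees C (a higher number here means faster removal of the compound, a lower number slower removal), compound 1 `CCn1c([C@@H](C)NS(=O)(=O)c2ccc(CC(C)C)cc2)nc2ccc(C(F)(F)F)cc21` gives > 100 mL.min-1.g-1, which is a limit of the assay and not a number. Compound 2 `CCCn1ncc(S(=O)(=O)N[C@H](C)c2nc3ccc(C(F)(F)F)cc3n2CC)c1C` gives > 100 mL.min-1.g-1, also a limit. Compound 3 `CCn1c([C@@H](C)NS(=O)(=O)c2cnn(C(C)C)c2C)nc2ccc(C(F)(F)F)cc21` gives > 100 mL.min-1.g-1, again a limit, so it stands level with the other two only as far as their limits show. Going by the values given here, the series so far therefore sits at the limit of > 100 mL.min-1.g-1 in this assay, at which 3 of the 3 values shown sit.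

Compound 4 `CCn1c([C@@H](C)NS(=O)(=O)c2cnc(C)n2C)nc2ccc(C(F)(F)F)cc21` carries 1,2-dimethyl-1H-imidazol-5-yl in place of 1-isopropyl-5-methyl-1H-pyrazol-4-yl on a sulfonyl sulfur.

Among the compounds with values here, three measured steps bear on this exchange: a step that the two limits leave unreadable from compound 1 to compound 2, a step that the two limits leave unreadable from compound 1 to compound 3 and a step that the two limits leave unreadable from compound 2 to compound 3. None of them has a readable size, so they fix no size for the new step. The expectation is tentative, and this assay may well report only a limit again. The expected change is an at least 1.4-fold lower number from compound 3 to compound 4 (0.15 log units; that floor lies within the scatter), towards slower removal if it can be read at all. Compound 4 is estimated at 70 mL.min-1.g-1, with an expected range from 25 mL.min-1.g-1 to 200 mL.min-1.g-1.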

Compound 4, intrinsic clearance in microsomes: 58 mL.min-1.g-1
Compound 4: middle estimate off by 1.2-fold (0.08 log units), on the high side; low and high end bracket the measured number.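

Compound 4 is the only compound shown that gives a number rather than a limit, so the group on the sulfonyl sulfur can bring the read-out of this assay into its readable range: (the limit of > 100 mL.min-1.g-1 in this assay, at which 3 of the 4 values shown sit). The exchange for 1,2-dimethyl-1H-imidazol-5-yl is an at least 1.7-fold lower number from compound 3 to compound 4 (0.23 log units; that floor lies within the scatter) and an at least 1.7-fold lower number from compound 2 to compound 4 (0.23 log units; that floor lies within the scatter) and also an at least 1.7-fold lower number from compound 1 to compound 4 (0.23 log units; that floor lies within the scatter) for the replacement of 4-isobutylphenyl. From the compounds shown here alone, these are floors only, so the full size of each step remains unknown, and the steps among compound 1, compound 2 and compound 3 cannot be read.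

The entering group differs from the 1-isopropyl-5-methyl-1H-pyrazol-4-yl group both in its ring and in having 7 heavy atoms rather than 9, and the compounds shown do not separate these two changes. Going by these compounds, what a pyridine ring or a carboxylic acid at this place on the sulfonyl sulfur would give remains open.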